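The source may report more compounds than this note shows. Statements on the series, on what has been measured and on what is new or still open speak of the compounds shown alone.

Compound 3 `CC1=CC[C@@H]([C@@](C)(O)CCCC(C)(C)NC(=S)N/N=C\c2ccc(N(C)C)cc2)CC1` gives 13700 nM in a functional assay on PCO3 cells (Homo sapiens) for cytotoxicity, read by sulforhodamine B assay; on this read-out lower numbers stand for stronger inhibition of growth and higher numbers for weaker inhibition of growth. Compound 1 `CC1=CC[C@@H]([C@@](C)(O)CCCC(C)(C)NC(=S)N/N=C\c2ccccc2)CC1` gives 8470 nM. Compound 2 `CC1=CC[C@@H]([C@@](C)(O)CCCC(C)(C)NC(=S)N/N=C\c2ccc(C)cc2)CC1` gives 6750 nM.

Among these three numbers, compound 3 stands highest: its nearest neighbour is compound 1 and the furthest is compound 2, as a 2.0-fold higher number from compound 2 to compound 3 (0.31 log units; beyond the scatter) shows. Compound 4 `CC1=CC[C@@H]([C@@](C)(O)CCCC(C)(C)NC(=S)N/N=C\c2cccc([N+](=O)[O-])c2)CC1` differs from compound 3 in one place: 3-nitrophenyl in place of 4-(dimethylamino)phenyl on a carbon with a double bond to nitrogen. For the measured compounds named here, the steps that bear on this change are those that brought in the dimethylamino group, a 1.6-fold higher number from compound 1 to compound 3 (0.21 log units; within the scatter) and a 2.0-fold higher number from compound 2 to compound 3 (0.31 log units; beyond the scatter); nothing measured speaks to the nitro group itself. Undoing the dimethylamino group is therefore expected to lower the number modestly, toward compound 1 and compound 2, as a 1.7-fold lower number from compound 3 to compound 4 (0.23 log units; within the scatter). Compound 4 is thus estimated at 8000 nM, in the range 3500 nM to 18000 nM.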

Compound 4, concentration for 50% growth inhibition: 5600 nM
For compound 4 the middle estimate is 1.4-fold (0.15 log units) above the measured one; low and high end bracket the measured number.
By their numbers in this assay, from the lowest: compounds 4, 2, 1 and 3 (each within the scatter of the next, the first and the last beyond it).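

In this assay, the step to 3-nitrophenyl on the carbon with a double bond to nitrogen is beyond the scatter (a 2.4-fold lower number from compound 3 to compound 4 (0.39 log units; beyond the scatter)), so compound 3 now stands apart from two compounds rather than one. Nitro in place of hydrogen stays within the scatter (a 1.5-fold lower number from compound 1 to compound 4 (0.18 log units; within the scatter)), as does 3-nitrophenyl in place of 4-methylphenyl (a 1.2-fold lower number from compound 2 to compound 4 (0.08 log units; within the scatter)), so compounds 1, 2 and 4 cannot be told apart. Nothing available explains these differences.

As far as these compounds go, how a carboxylic acid or a primary amine on this aromatic ring would read remains open.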